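A few compounds are considered here, and "the series" means these few. Any claim that something is new, unique, unknown or untested is made for them only; others in the source may bear on it.

Compound 1 `CCCCCCOc1ccc(-n2cnnc2)cc1` gives 9.8 mg/kg in a functional assay on the whole organism (strain C57B/6) with Mus musculus as the target, in the maximal electroshock model; a lower number here means that less compound is needed, a higher number that more compound is needed for the effect.
Compound 2 `CCCCCCOc1ccc(-n2cnnc2C)cc1` gives 22.8 mg/kg in this assay.
Compound 3 `CCCCCCCCCc1nncn1-c1ccc(OCCCCCC)cc1` reaches only the limit of > 40 mg/kg in this assay, so no number is known for it.

Among the two numbers, compound 2 holds the higher one; its nearest neighbour is compound 1, and the step is a 2.3-fold higher number from compound 1 to compound 2 (0.37 log units; beyond the scatter). Compound 4 `CCCCCCOc1ccc(-n2cnnc2-c2ccc(Cl)cc2)cc1` differs from compound 2 by 4-chlorophenyl in place of methyl on an aromatic carbon. Among the measured compounds shown here, the steps that bear on this change are a 2.3-fold higher number from compound 1 to compound 2 (0.37 log units; beyond the scatter) and an at least 4.0-fold higher number from compound 1 to compound 3 (0.61 log units; beyond the scatter), both raising the number when a group is placed on this carbon, while an at least 1.7-fold higher number from compound 2 to compound 3 (0.24 log units; that floor lies within the scatter) has a floor inside the scatter. A further, larger group is therefore expected to raise the number again, with an estimated step of a 1.8-fold higher number from compound 2 to compound 4 (0.24 log units; within the scatter). Compound 4 is estimated at 40 mg/kg, within 18 mg/kg to 90 mg/kg; a limit is possible because of the limit of > 40 mg/kg in this assay, at which 1 of the 3 values shown sits.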

Compound 4, dose for half-maximal effect: 19.7 mg/kg
For compound 4 the middle estimate is 2.0-fold (0.31 log units) above the measured one; low and high end bracket the measured number.
By their numbers in this assay, from the lowest: compounds 1, 4 and 2 (each within the scatter of the next, the first and the last beyond it). At a limit, above all of these: compound 3.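

The carbon between two ring nitrogen atoms accepts a much larger group without a clear change in this assay: 4-chlorophenyl in place of methyl gives a 1.2-fold lower number from compound 2 to compound 4 (0.06 log units; within the scatter). The earlier rise with group size therefore does not extend to this aromatic group, and even against hydrogen the result is a 2.0-fold higher number from compound 1 to compound 4 (0.30 log units; within the scatter). Compound 3 stands at a limit, and against nonyl the change gives an at least 2.0-fold lower number from compound 3 to compound 4 (0.30 log units; that floor lies within the scatter), so no difference is established.

Going by these compounds, whether the chlorine matters remains open, since plain phenyl would be needed to test it. How an amine or a carboxylic acid at this carbon would behave is also unknown.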